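This account rests on a few compounds, and the source may have more. Where it says the series, first, only, none or still open, it means among the compounds named here.

Three compounds of one series were measured in an assay on isolated protein for inhibition of Polyunsaturated fatty acid 5-lipoxygenase (Rattus norvegicus); a higher number here means a weaker inhibitor, a lower number a stronger inhibitor. Compound 1 `CSC1CN(c2ccccc2)NC1=O` gave 320 nM. Compound 2 `O=C1NN(c2ccccc2)CC1SCc1ccccc1` gave 180 nM. Compound 3 `COCCC1CN(c2ccc(OCc3ccccc3)cc2)NC1=O` gave 500 nM. How the core of compound 3 differs from that of compound 2 is not broken down here; compound 3 stands within the scatter of compound 1 but beyond it from compound 2. Among the measured compounds shown here, the one single-point change within the measured set is hydrogen in place of phenyl on a saturated chain carbon bound to a sulfur, which produced a 1.8-fold higher number from compound 2 to compound 1 (0.25 log units; within the scatter).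

Compound 4 `COCCC1CN(c2ccc(OC)cc2)NC1=O` has not yet been measured in this assay. It arises from compound 3 by hydrogen in place of phenyl on a saturated chain carbon bound to an oxygen on an aromatic ring. The change is the same kind of change as that from compound 2 to compound 1, but the place differs: there the hydrogen entered on a saturated chain carbon bound to a sulfur, here on a saturated chain carbon bound to an oxygen on an aromatic ring. Resting on the earlier step of a 1.8-fold higher number from compound 2 to compound 1 (0.25 log units; within the scatter), the step from compound 3 to compound 4 is expected to be a 1.6-fold higher number from compound 3 to compound 4 (0.20 log units; within the scatter). Compound 4 is therefore estimated at 800 nM, with a range from 350 nM to 1800 nM.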

Compound 4, half-maximal inhibitory concentration in the Polyunsaturated fatty acid 5-lipoxygenase assay: 1460 nM
Compound 4: the middle estimate sits 1.8-fold (0.26 log units) below what was measured, and the stated range covers the measured number.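

In the Polyunsaturated fatty acid 5-lipoxygenase assay, hydrogen in place of phenyl on a saturated chain carbon bound to an oxygen on an aromatic ring gave a 2.9-fold higher number from compound 3 to compound 4 (0.47 log units; beyond the scatter), and this step cannot be told apart from the earlier one on the other core: the same change on two cores in the Polyunsaturated fatty acid 5-lipoxygenase assay, a 1.8-fold higher number (0.25 log units; within the scatter) from compound 2 to compound 1 and a 2.9-fold higher number (0.47 log units; beyond the scatter) from compound 3 to compound 4, 1.6-fold (0.22 log units) apart, within the scatter of two such steps. The change therefore carried from one core to the other without a measurable difference in size, but with a single pair on each core this does not show that its size is fixed, or that it would hold on any further core. The same pair also parted in a physicochemical assay for lipophilicity; a higher number here means a more lipophilic compound, a lower number a more polar compound (compound 3 gives 2.22 and compound 4 gives 0.45), so the weaker inhibition of compound 4 may go along with its lower lipophilicity, although one pair cannot separate the two: the measured partition coefficient of compound 3, 2.22, and of compound 4, 0.45, a number 1.77 log units lower (beyond the scatter).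

The compounds shown leave open how a longer chain or a cyclohexyl ring would read in place of the phenyl on that carbon in the Polyunsaturated fatty acid 5-lipoxygenase assay. They also leave open whether an amine or a carboxylic acid carried there would fit the same picture.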